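A few compounds are considered here, and "the series" means these few. Any claim that something is new, unique, unknown or untested is made for them only; others in the source may bear on it.

Compound 1 `CCc1nc2ccccc2n1CCCOc1ccccc1` gives > 50 uM in an ADME assay on Vero cells (Chlorocebus sabaeus) for cytotoxicity, read by luminescence, with a stated time of 2 days (a higher number here means that more compound is tolerated, a lower number that less compound is tolerated), which is a limit of the assay rather than a number.
Compound 2 `CCc1nc2ccccc2n1CCCCOc1ccccc1` gives 21 uM in this assay.
Compound 3 `CCc1nc2ccccc2n1CCCCOc1cccc(Cl)c1` gives 22 uM in this assay.

Among the two numbers, compound 3 stands highest, with compound 2 nearest, and the two lie within the scatter of each other; the remaining value is only a limit. Compound 4 `CCc1nc2ccccc2n1CCCCOc1ccc(Cl)cc1F` differs from compound 3 by 4-chloro-2-fluorophenyl in place of 3-chlorophenyl on an oxygen on a saturated carbon. Among the measured compounds shown here, the only measured step, a 1.0-fold higher number from compound 2 to compound 3 (0.02 log units; within the scatter), concerns a chlorine and lies within the scatter; no measured step adds a fluorine to the same ring. Compound 4 is therefore expected to show a 1.2-fold lower number from compound 3 to compound 4 (0.09 log units; within the scatter), nothing beyond the scatter. Compound 4 is estimated at 18 uM, between 8 uM and 45 uM.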

Compound 4, half-maximal toxic concentration: 5.7 uM
For compound 4 the middle estimate is 3.2-fold (0.50 log units) above the measured one; the measured number lies below the stated range.
By their numbers in this assay, from the lowest: compound 4; then compounds 2 and 3 (each within the scatter of the next). At a limit, above all of these: compound 1.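

In this assay the ring on this oxygen proves sensitive to change: swapping in 4-chloro-2-fluorophenyl gives a 3.9-fold lower number from compound 3 to compound 4 (0.59 log units; beyond the scatter) and also a 3.7-fold lower number from compound 2 to compound 4 (0.57 log units; beyond the scatter), whereas the earlier chlorine step stayed within the scatter. So the absence of an effect from that single chlorine does not hold for every change to this ring. Nothing measured here explains the drop.

Going by these compounds, the step changes the chlorine's place and adds a fluorine at once, so their separate shares stay open. On these data alone, compounds carrying 4-chlorophenyl or 2-fluorophenyl alone on the same chain would separate them, and an amine on this ring remains unexplored territory here.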